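Amide variation on the dimethoxy-tetralin acetamide series

The source may report more compounds than this note shows. Statements on the series, on what has been measured and on what is new or still open speak of the compounds shown alone.

Measured so far:
compound 1 `CCCCNC(=O)CC1CCc2cc(OC)c(OC)cc21`: 25%
compound 2 `COc1cc2c(cc1OC)C(CC(=O)N1CCCC1)CC2`: 24.2%
compound 3 `COc1cc2c(cc1OC)C(CC(=O)N1CCNCC1)CC2`: 40.6%

All three were run in a functional assay on the whole organism (strain Wistar) for inhibition, with Rattus norvegicus as the target, read by paw edema, with stated times of 60 min and 4 h, at a dose of 100 mg/kg by the oral route; a lower number here means less inhibition, a higher number more inhibition at the dose given (going by the name of the read-out). Compound 3 stands highest of the three numbers: the step of a number 15.6 percentage points higher from compound 1 to compound 3 (beyond the scatter) and the step of a number 16.4 percentage points higher from compound 2 to compound 3 (beyond the scatter) are both beyond the scatter, while compound 1 and compound 2 sit within the scatter of each other, a number 0.8 percentage points lower from compound 1 to compound 2 (within the scatter).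

Compound 4 `COc1cc2c(cc1OC)C(CC(=O)NCCO)CC2` is not yet measured. It differs from compound 3 by (2-hydroxyethyl)amino in place of piperazin-1-yl on a carbonyl carbon. Going by the values given here, the steps that bear on this change are those leading into the piperazin-1-yl compound, a number 15.6 percentage points higher from compound 1 to compound 3 (beyond the scatter) and a number 16.4 percentage points higher from compound 2 to compound 3 (beyond the scatter): both were modest gains on replacing an amide group that was not piperazin-1-yl. Leaving piperazin-1-yl again is therefore expected to give back part of that gain, a modest downward step, a number 10.6 percentage points lower from compound 3 to compound 4 (beyond the scatter), though no measured step tells how (2-hydroxyethyl)amino itself compares with butylamino or pyrrolidin-1-yl.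

Compound 4 is estimated at 30% in this assay, with a range from 15% to 45%.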

Compound 4, a percentage reported as inhibition, in the whole organism at one dose (the size of the read-out at that dose, not a potency): 9.37%
Compound 4: middle estimate off by 20.6 percentage points, on the high side, and the stated range ends above it.
By their numbers in this assay, from the lowest: compound 4; then compounds 2 and 1 (each within the scatter of the next); then compound 3.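

In this assay, the amide position on the carbonyl carbon can now be seen to lower the number as well as raise it: (2-hydroxyethyl)amino in place of pyrrolidin-1-yl gives a number 14.8 percentage points lower from compound 2 to compound 4 (beyond the scatter) and falls beyond the scatter. The open chains also differ, since hydroxy in place of ethyl, two bonds along the chain from an amide-type nitrogen, gives a number 15.6 percentage points lower from compound 1 to compound 4 (beyond the scatter) and so the end of the chain matters here. Leaving piperazin-1-yl for (2-hydroxyethyl)amino gives a number 31.2 percentage points lower from compound 3 to compound 4 (beyond the scatter) and this large step spans the whole measured spread of the series, with no data here giving a cause for any of these steps.

Still open, going by these compounds, is whether the number for compound 3 is tied to piperazin-1-yl itself or would hold with another ring such as morpholin-4-yl or 4-methylpiperazin-1-yl. Also open, on these data alone, is how a longer hydroxyalkyl chain or a methoxyethyl chain on the amide nitrogen would compare with compound 4.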